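The compounds below may be only part of what the source reports. "The series", "measured", "known", "first", "only" and "open" are said of these compounds alone.

Of the compounds shown here, three sharing one core have been tested in a functional assay on DU-145 cells (Homo sapiens) for inhibition, read by trypan blue exclusion, with a stated time of 72 h; on this read-out lower numbers stand for stronger inhibition and higher numbers for weaker inhibition: compound 1 (`Cn1c(=O)c(S(=O)(=O)c2ccc(Cl)cc2Cl)cc2cnc(Nc3ccc4[nH]ccc4c3)nc21`) gives 1000 nM, compound 2 (`Cn1c(=O)c(S(=O)(=O)c2ccc(C(=O)O)cc2)cc2cnc(Nc3ccc4[nH]ccc4c3)nc21`) gives 10000 nM, and compound 3 (`Cn1c(=O)c(C(=O)Nc2ccc(F)cc2)cc2cnc(Nc3ccc4[nH]ccc4c3)nc21`) gives 5000 nM. Compound 3 therefore sits within the usual scatter of compound 2 and clearly apart from compound 1.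

The next structure, compound 4 (`Cn1c(=O)c(S(=O)(=O)Nc2ccc(F)cc2)cc2cnc(Nc3ccc4[nH]ccc4c3)nc21`), alters compound 3 in one place: (4-fluorophenyl)sulfamoyl in place of (4-fluorophenyl)carbamoyl on an aromatic carbon. Put simply, (4-fluorophenyl)sulfamoyl stands in place of (4-fluorophenyl)carbamoyl on an aromatic carbon, so a sulfonyl replaces the carbonyl while the 4-fluorophenyl ring stays.

Among the compounds with values here, no measured step makes exactly this swap. The closest is a 5.0-fold higher number from compound 1 to compound 3 (0.70 log units; beyond the scatter), where (4-fluorophenyl)carbamoyl replaced (2,4-dichlorophenyl)sulfonyl, but that step changes two things at once. It hints that a compound carrying a sulfonyl might give a lower number than compound 3. Compound 2 warns against a simple rule, since it also carries a sulfonyl and a 10-fold higher number from compound 1 to compound 2 (1.00 log units; beyond the scatter) goes the other way.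

In this assay, only a small shift towards a lower number is therefore expected, not clearly beyond the scatter. The expected step is a 1.7-fold lower number from compound 3 to compound 4 (0.22 log units; within the scatter). The estimate for compound 4 is 3000 nM, with an expected range from 1000 nM to 10000 nM.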

Compound 4, half-maximal inhibitory concentration: 5000 nM
Compound 4: the middle estimate sits 1.7-fold (0.22 log units) below what was measured; measured number inside the range.
By their numbers in this assay, from the lowest: compound 1; then compounds 3, 4 and 2 (each within the scatter of the next).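

Holding the 4-fluorophenyl ring in place on this aromatic carbon of the shared core, putting a sulfonyl where the carbonyl stood in this assay gives no change at the digits printed from compound 3 to compound 4 (within the scatter), so here the amide and sulfonamide links cannot be told apart. With the sulfonyl kept, the group on the sulfur can matter: (4-fluorophenyl)amino in place of 4-carboxyphenyl gives a 2.0-fold lower number from compound 2 to compound 4 (0.30 log units; within the scatter), whereas (4-fluorophenyl)amino in place of 2,4-dichlorophenyl gives a 5.0-fold higher number from compound 1 to compound 4 (0.70 log units; beyond the scatter), which shows that the sulfonyl alone does not bring a number as low as that of compound 1. Nothing measured here offers a reason for these numbers.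

Still open, on these data alone, is whether the lower number of compound 1 goes with the chlorines of 2,4-dichlorophenyl or with an aryl ring joined directly to the sulfur, a question that a 4-fluorophenyl group bonded straight to the sulfonyl would help to settle. The compounds shown also leave open how a cyclic amine such as morpholine on the sulfonyl, or a longer chain between the sulfur and the ring, would read in this assay.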